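A few compounds are considered here, and "the series" means these few. Any claim that something is new, unique, unknown or untested is made for them only; others in the source may bear on it.

Compound 1 `Cc1ccc2[nH]c(=O)c(CN(Cc3ccc(C(C)(C)C)cc3)C(C)c3ccc(F)cc3)cc2c1` sits at the limit in a toxicity assay on MDCK cells (Canis lupus familiaris) for cytotoxicity, read by crystal violet staining, with a stated time of 48 h (on this read-out higher numbers stand for lower toxicity in this test and lower numbers for higher toxicity in this test), giving > 33000 nM. Within the data shown here, compound 2 `CCc1ccc2[nH]c(=O)c(CN(Cc3ccc(C(C)(C)C)cc3)C(C)c3ccc(F)cc3)cc2c1` gives 2800 nM in this assay, the only number in the set. The step of an at least 11-fold lower number from compound 1 to compound 2 (1.07 log units; beyond the scatter) is large. Compound 3 `CC(C)c1ccc2[nH]c(=O)c(CN(Cc3ccc(C(C)(C)C)cc3)C(C)c3ccc(F)cc3)cc2c1` differs from compound 2 by methyl in place of hydrogen on a saturated chain carbon bound to an aromatic carbon and a saturated chain carbon, the same kind of change cut one bond further out. Among the measured compounds shown here, only that single measured step bears on it, so a further lowering of the number in this assay is expected, though smaller and uncertain. For compound 3 a value of 1500 nM is expected, with a range from 400 nM to 6000 nM. This corresponds to an expected 1.9-fold lower number from compound 2 to compound 3 (0.27 log units; within the scatter).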

Compound 3, half-maximal cytotoxic concentration: 13100 nM
Estimate against measurement, compound 3: 8.7-fold (0.94 log units) below, outside the stated range (above it).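

In this assay ethyl to isopropyl gives a 4.7-fold higher number from compound 2 to compound 3 (0.67 log units; beyond the scatter) and so runs against the lowering seen from methyl to ethyl, the same kind of change. Isopropyl in place of methyl still gives an at least 2.5-fold lower number from compound 1 to compound 3 (0.40 log units; beyond the scatter) and so does not fully undo that lowering. Compound 1 gives only a limit of the assay, so the full size of its steps stays unread: the limit of > 33000 nM in this assay, at which 1 of the 3 values shown sits.

Open, going by these compounds, is whether a longer chain such as n-propyl, or a cyclopropyl ring, on this aromatic carbon follows ethyl or isopropyl. Three compounds also cannot show whether ethyl is an isolated low point in this series.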